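Shortening the chain on a propiolate enol ether

The source may hold more compounds than are shown below. What is called first, only, known or untested is meant among the compounds shown, and "the series" means these compounds.

Compound 1 `CCCCCCCCCCC(C#CC(=O)OC)O/C=C/C(=O)OC` carries an octyl chain on the saturated carbon that links the alkyne and the enol ether. Going by the values given here, in a functional assay on SW1573 cells (Homo sapiens) for antiproliferative activity, read by sulforhodamine B assay, with a stated time of 48 h (on this read-out higher numbers stand for weaker inhibition of growth and lower numbers for stronger inhibition of growth), compound 1 gives 2000 nM, the lower of the two numbers so far. Compound 2 `Cc1ccc(S(=O)(=O)C#CC(O/C=C/S(=O)(=O)c2ccc(C)cc2)C(C)C)cc1` is built around the same kind of linking carbon but with sulfonyl groups in place of the esters, and in this assay compound 2 gives 3200 nM; the two values lie within the scatter of each other, so the two compounds cannot be told apart on these numbers.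

Compound 3 `CCC(C#CC(=O)OC)O/C=C/C(=O)OC` differs from compound 1 in one place: hydrogen in place of octyl on a saturated chain carbon, three bonds along the chain from an oxygen on an unsaturated carbon and a triple-bonded carbon. Among the compounds with values here, no measured pair in this set shows what such a removal of chain does, so the expectation rests on compound 1 alone. The account expects that the loss of the octyl chain moves the value upward in this assay, toward weaker inhibition of growth, by a step somewhat beyond the scatter, so that the estimated step is a 2.5-fold higher number from compound 1 to compound 3 (0.40 log units; beyond the scatter). For compound 3 the estimate in this assay is 5000 nM, expected to fall between 1500 nM and 20000 nM.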

Compound 3, concentration for 50% growth inhibition: 540 nM
Compound 3: middle estimate off by 9.3-fold (0.97 log units), on the high side, outside the stated range (below it).
By their numbers in this assay, from the lowest: compound 3; then compounds 1 and 2 (each within the scatter of the next).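

In this assay, the result shows that the octyl chain on this saturated chain carbon is not required for growth inhibition: hydrogen in place of octyl gives a 3.7-fold lower number from compound 1 to compound 3 (0.57 log units; beyond the scatter), so in this pair, removing the chain goes with stronger inhibition of growth rather than weaker. Going by these compounds alone, this is the first single-place change in the set, and thus the first direct reading of what this position tolerates; the shared core keeps its activity without the octyl group. No supporting data bear on why the number falls, so the step stands as an observation without an explanation.

A single pair fixes only the two ends of this change, and it leaves open whether a butyl chain on the same carbon would behave like the octyl chain of compound 1 or like the smaller substituent pattern of compound 3, and whether a longer chain would push the value further in the same direction. It also leaves open how an amine or a carboxylic acid at this place would read, and whether the same removal would have a similar effect in the sulfonyl series of compound 2.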